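Leaving 2,4,6-trimethylphenyl for 4-methoxyphenyl

The compounds below may be only part of what the source reports. "The series", "measured", "known", "first", "only" and "open" are said of these compounds alone.

In a functional assay on MDA-MB-231 cells (Homo sapiens) for inhibition, read by CCK-8 assay, with a stated time of 48 h (on this read-out higher numbers stand for weaker inhibition of growth and lower numbers for stronger inhibition of growth), compound 3 (`Cc1cc(C)c(Nc2nc(Nc3ccc(N4CCN(C)CC4)cn3)ncc2Cl)c(C)c1`) gives 21000 nM as the highest of three numbers, the weakest growth inhibition so far. On the same read-out compound 1 (`CC(C)c1ccc(Nc2nc(Nc3ccc(N4CCN(C)CC4)cn3)ncc2Cl)cc1`) gives 7020 nM and compound 2 (`CC(C)c1cccc(Nc2nc(Nc3ccc(N4CCN(C)CC4)cn3)ncc2Cl)c1`) gives 5590 nM and the step of a 1.3-fold lower number from compound 1 to compound 2 (0.10 log units; within the scatter) stays within the scatter. Next comes compound 4 (`COc1ccc(Nc2nc(Nc3ccc(N4CCN(C)CC4)cn3)ncc2Cl)cc1`), with 4-methoxyphenyl in place of 2,4,6-trimethylphenyl on a nitrogen on an aromatic ring. The steps of a 3.0-fold higher number from compound 1 to compound 3 (0.48 log units; beyond the scatter) and a 3.8-fold higher number from compound 2 to compound 3 (0.57 log units; beyond the scatter) bear on this change, and both are modest and beyond the scatter. Both isopropylphenyl compounds sit lower than compound 3, and the 4-methoxyphenyl group shares its name pattern with the 4-isopropylphenyl group of compound 1. Within the data shown here, no methoxy compound has been measured yet, so this comparison is only a rough guide. A modest fall is therefore expected, with the estimated step of a 2.6-fold lower number from compound 3 to compound 4 (0.42 log units; beyond the scatter) in this assay as the working figure. Compound 4 is estimated at 8000 nM with 3000 nM to 20000 nM as the expected range.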

Compound 4, concentration for 50% growth inhibition: 8020 nM
Beside the measured number, compound 4's estimate is 1.0-fold (0.00 log units) below it; the measured number falls inside the stated range.
By their numbers in this assay, from the lowest: compounds 2, 1 and 4 (each within the scatter of the next); then compound 3.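

In this assay, 4-methoxyphenyl in place of 2,4,6-trimethylphenyl on a nitrogen on an aromatic ring gives a step beyond the scatter (a 2.6-fold lower number from compound 3 to compound 4 (0.42 log units; beyond the scatter)), so compound 3 stays apart from the other three compounds. Methoxy in place of isopropyl on an aromatic carbon (a 1.1-fold higher number from compound 1 to compound 4 (0.06 log units; within the scatter)) and 4-methoxyphenyl in place of 3-isopropylphenyl (a 1.4-fold higher number from compound 2 to compound 4 (0.16 log units; within the scatter)) both stay within the scatter, so a group with one hydrogen-bond acceptor cannot be told apart here from either isopropylphenyl group. No evidence at hand accounts for the separate position of compound 3.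

Open, from the compounds shown here alone, is whether an amine, a carboxylic acid or a longer alkoxy chain in place of methoxy on an aromatic carbon would also stay within the scatter. Also open, going by these compounds, is which of the methyl groups of 2,4,6-trimethylphenyl goes with the higher number of compound 3.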